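A few compounds are considered here, and "the series" means these few. Any claim that something is new, unique, unknown or untested is made for them only; others in the source may bear on it.

Working notes on the series in a functional assay on U-251 cells (Homo sapiens) for antiproliferative activity, read by MTT assay, with a stated time of 72 h; on this read-out higher numbers stand for weaker inhibition and lower numbers for stronger inhibition. Of the compounds shown here, three have numbers so far. Compound 2 `O=C(Nc1ccc(Cl)c(-c2nnc3c(Cl)cccn23)c1)c1cccc(Cl)c1` gives 43100 nM, the lowest of the three numbers, but neither neighbour separates from it beyond the scatter: compound 3 `CS(=O)(=O)c1ccc(C(=O)Nc2ccc(Cl)c(-c3nnc4c(Cl)cccn34)c2)c(Cl)c1` gives 44600 nM, and compound 1 `Cc1nc(C(=O)Nc2ccc(Cl)c(-c3nnc4c(Cl)cccn34)c2)cs1` gives 74300 nM. Going by the values given here, the only single-point step among them runs a 1.7-fold lower number from compound 1 to compound 2 (0.24 log units; within the scatter), so exchanging one group on the carbonyl carbon has not moved the read-out beyond the noise of the assay.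

Compound 4 `O=C(Nc1ccc(Cl)c(-c2nnc3c(Cl)cccn23)c1)c1c(F)cccc1Cl` is the next member to be run. It differs from compound 2 by 2-chloro-6-fluorophenyl in place of 3-chlorophenyl on a carbonyl carbon. Among the compounds with values here, the one comparable step, from compound 1 to compound 2, stayed within the scatter, and no other change at the carbonyl carbon has been tested, so no step beyond the scatter is expected for compound 4 in this assay either. Compound 4 is therefore estimated at 45000 nM, with a range of 15000 nM to 135000 nM. The expected step from compound 2 is a 1.0-fold higher number from compound 2 to compound 4 (0.02 log units; within the scatter).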

Compound 4, half-maximal inhibitory concentration: > 100000 nM
Compound 4: a limit, no number; the forecaster's own chance of this, stated with the estimate: 25%; middle value at least 2.2-fold (0.34 log units) from the limit.
By their numbers in this assay, from the lowest: compounds 2, 3 and 1 (each within the scatter of the next). At a limit, above all of these: compound 4.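

In this assay compound 4 stands as a limit of the assay and not as a number: the limit of > 100000 nM in this assay, at which 1 of the 4 values shown sits. Going by these compounds alone, the carbonyl carbon is not a silent place: 2-chloro-6-fluorophenyl in place of 3-chlorophenyl gives an at least 2.3-fold higher number from compound 2 to compound 4 (0.36 log units; beyond the scatter), the first step here that lies beyond the scatter. The same group in place of 2-methyl-1,3-thiazol-4-yl gives an at least 1.3-fold higher number from compound 1 to compound 4 (0.12 log units; that floor lies within the scatter), so that comparison rests on a floor and sets no order between the two.

Open, from the compounds shown here alone, is how 2-chlorophenyl or 2-fluorophenyl alone would read on this carbonyl carbon, which would show which part of the 2-chloro-6-fluorophenyl group goes with the step. Also open, going by these compounds, is how an amine or a carboxylic acid on the phenyl ring would read at this place.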